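This account rests on a few compounds, and the source may have more. Where it says the series, first, only, none or still open, it means among the compounds named here.

The measured compounds:
Compound 1 `COc1ccc(-c2[nH]c3cc(OC)cc(OC)c3c(=O)c2I)cc1` gives > 86200 nM in an ADME assay on BJ cells (Homo sapiens) for antiproliferative activity, with a stated time of 72 h (a lower number here means that less compound is needed, a higher number that more compound is needed for the effect), which is a limit of the assay.
Compound 2 `COC(=O)c1cc(=O)c2c(OC)cc(OC)cc2n1S(=O)(=O)c1ccc(C)cc1` gives 139000 nM in this assay.
Compound 3 `COc1ccc(-c2cc(=O)c3c(OC)cc(OC)cc3n2S(=O)(=O)c2ccc([N+](=O)[O-])cc2)cc1` gives > 29300 nM in this assay, again a limit and not a number.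

Compound 3 therefore stands at the limit of > 29300 nM in this assay, at which 1 of the 3 values shown sits. Compound 1 stands at the limit of > 86200 nM in this assay, at which 1 of the 3 values shown sits. Going by the values given here, only compound 2 gives a number, and no pair of these three differs in just one place, so no measured step is available.

Compound 4 `COc1ccc(-c2cc(=O)c3c(OC)cc(OC)cc3n2S(=O)(=O)c2cccc(Br)c2)cc1` differs from compound 3 by 3-bromophenyl in place of 4-nitrophenyl on a sulfonyl sulfur. Since compound 3 sits at a limit, the step from compound 3 to compound 4 in this assay is expected to be a step that the limit leaves unreadable from compound 3 to compound 4, none beyond the scatter. Compound 4 is estimated at 40000 nM, between 15000 nM and 150000 nM.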

Compound 4, half-maximal effective concentration: > 58600 nM
Compound 4 gave a limit, no number; the forecaster's own chance of this, stated with the estimate: 60%; middle value at least 1.4-fold (0.16 log units) from the limit.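

Going by these compounds alone, compound 3 and compound 4 both sit at limits, so no step between them can be read. As far as these compounds go, whether 3-bromophenyl or 4-nitrophenyl on the sulfonyl sulfur changes the concentration needed in this assay stays open.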